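Methylsulfanyl for Cyano on an Arylpiperazine Antagonist

The source may hold more compounds than are shown below. What is called first, only, known or untested is meant among the compounds shown, and "the series" means these compounds.

Compound 1: `COc1ccccc1N1CCN(CCCOc2ccccc2C(=O)N(C)C)CC1`, 3.98 nM
Compound 2: `CN(C)C(=O)c1cccnc1NCCCN1CCN(c2ccccc2C#N)CC1`, 2 nM

In a functional assay for antagonist activity at Alpha-1A adrenergic receptor (Oryctolagus cuniculus) (a higher number here means weaker binding, a lower number tighter binding), compound 1 gives 3.98 nM and compound 2 gives 2 nM. The two numbers lie within the scatter of each other, so neither compound can be set above the other in this assay; compound 2 simply stands next to compound 1 with a gap that repeated measurements could erase.

Compound 3, `CSc1ccccc1N1CCN(CCCNc2ncccc2C(=O)N(C)C)CC1`, has not yet been measured. It differs from compound 2 in one place: methylsulfanyl in place of cyano on an aromatic carbon. Among the compounds with values here, no pair of measured compounds shows what such an exchange does in this assay, so the expectation rests on compound 2 alone and on the small size of the change. With nothing in the data pointing either way, the expected step is a 1.3-fold higher number from compound 2 to compound 3 (0.10 log units; within the scatter), which does not go beyond the scatter. Compound 3 is therefore estimated to give 2.5 nM in this assay, with a range from 0.8 nM to 8 nM.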

Compound 3, dissociation constant: 0.631 nM
The estimate for compound 3 lay 4.0-fold (0.60 log units) above the measured number, and the stated range ends above it.
By their numbers in this assay, from the lowest: compound 3; then compounds 2 and 1 (each within the scatter of the next).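

Going from 2-cyanophenyl to 2-(methylsulfanyl)phenyl gives a 3.2-fold lower number from compound 2 to compound 3 (0.50 log units; beyond the scatter) in this assay and so shows that this aromatic carbon, ortho to a large group, is not indifferent to what it carries. Cyano and methylsulfanyl have the same count of heavy atoms and of hydrogen-bond acceptors, neither has a hydrogen-bond donor and neither has a net charge, so these counts do not separate the two groups even though the number moves beyond the scatter. Nothing in the available data accounts for the step.

From the compounds shown here alone, the finding rests on a single pair of compounds, so it remains open whether methylsulfanyl would bring a similar step on the ether-linked scaffold of compound 1, which carries methoxy on the corresponding ring. Going by these compounds, it also remains open how far the trend would extend to other groups on this carbon, such as ethylsulfanyl, methylsulfonyl or a chlorine atom, and whether sulfur itself matters or only the group as a whole.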